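A few compounds are considered here, and "the series" means these few. Any claim that something is new, unique, unknown or untested is made for them only; others in the source may bear on it.

Working notes on the series. Three compounds sharing one core have numbers in a functional assay for inhibition, with Homo sapiens as the target (a lower number here means a stronger inhibitor, a higher number a weaker inhibitor), and they sit close together. Compound 1 `CC(C)(C)Sc1c(CC(C)(C)C(=O)O)n(Cc2ccc(Cl)cc2)c2ccc(CCc3ccc4ccccc4n3)cc12` gives 4 nM and compound 2 `CC(C)(C)Sc1c(CC(C)(C)C(=O)O)n(Cc2ccc(Cl)cc2)c2ccc(OCc3ccc4cc(F)ccc4n3)cc12` gives 2 nM in this read-out, while compound 3 `CC(C)(C)Sc1c(CC(C)(C)C(=O)O)n(Cc2ccc(Cl)cc2)c2ccc(OCc3cccc(Cl)n3)cc12` gives 3 nM and cannot be separated from either. The two steps that reach compound 3 (a 1.3-fold lower number from compound 1 to compound 3 (0.12 log units; within the scatter) and a 1.5-fold higher number from compound 2 to compound 3 (0.18 log units; within the scatter)) both stay within the scatter.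

Next is compound 4 `CC(C)(C)Sc1c(CC(C)(C)C(=O)O)n(Cc2ccc(Cl)cc2)c2ccc(OCc3cnccn3)cc12` with pyrazin-2-yl in place of 6-chloropyridin-2-yl on a saturated chain carbon bound to an oxygen on an aromatic ring. For the measured compounds named here, the closest precedent is the replacement of 6-fluoroquinolin-2-yl by 6-chloropyridin-2-yl at that same place (a 1.5-fold higher number from compound 2 to compound 3 (0.18 log units; within the scatter)), which left the number within the scatter. The replacement of 2-(quinolin-2-yl)ethyl by (6-chloropyridin-2-yl)methoxy (a 1.3-fold lower number from compound 1 to compound 3 (0.12 log units; within the scatter)) did the same. Going by the values given here, no measured compound carries pyrazin-2-yl, so neither step tests this exact change, and the range stays wide.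

A modest move toward a higher number is expected, with the estimated step being a 2.7-fold higher number from compound 3 to compound 4 (0.43 log units; beyond the scatter) in this assay terms. The estimate for compound 4 is 8 nM (expected range 2 nM to 30 nM).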

Compound 4, half-maximal inhibitory concentration: 4 nM
Compound 4: middle estimate off by 2.0-fold (0.30 log units), on the high side; the measured number falls inside the stated range.
By their numbers in this assay, from the lowest: compounds 2, 3, 1 and 4 (each within the scatter of the next).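

In this assay the place on a saturated chain carbon bound to an oxygen on an aromatic ring now accepts pyrazin-2-yl, a ring with 2 hetero atoms and no chlorine, with no separable effect on the number (a 1.3-fold higher number from compound 3 to compound 4 (0.12 log units; within the scatter)), and the step from the larger fused group stays just as unresolved (a 2.0-fold higher number from compound 2 to compound 4 (0.30 log units; within the scatter)). The exchange of the whole arm on the aromatic carbon, (pyrazin-2-yl)methoxy in place of 2-(quinolin-2-yl)ethyl, gives the same picture (no change at the digits printed from compound 1 to compound 4 (within the scatter)), so the four compounds form one group in which every listed step lies within the scatter, and the chlorine of compound 3 is not required for a number in this range. Nothing in the available data offers an account of why these aromatic groups cannot be told apart.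

All the groups shown at this place are aromatic rings containing nitrogen, so it remains open whether a saturated amine such as morpholine, a carboxylic acid or a plain phenyl ring would stay in this range. Also open, from the compounds shown here alone, is whether a longer chain between the oxygen and the ring would move the number beyond the scatter.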